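Shortening the Amide Side Chain: Compound 2 to Compound 4

This account rests on a few compounds, and the source may have more. Where it says the series, first, only, none or still open, it means among the compounds named here.

Compound 1 `CC(C)(C)OC(=O)NC1CCCN(C(=O)CN2CN(c3ccccc3)C3(CCN(C(=O)c4ccc(C5CCCCC5)cc4)CC3)C2=O)C1` gives 4400 nM in an assay on HEK293 cells for displacement of a labelled ligand from NPC1-like intracellular cholesterol transporter 1 (Homo sapiens); on this read-out lower numbers stand for stronger inhibition and higher numbers for weaker inhibition.
Compound 2 `COC(=O)CCNC(=O)CN1CN(c2ccccc2)C2(CCN(C(=O)c3ccc(C4CCCCC4)cc3)CC2)C1=O` gives 12900 nM in this assay.
Compound 3 `COC(=O)CCNC(=O)CN1CN(c2ccccc2)C2(CCN(C(=O)c3ccc(C(C)(C)C)cc3)CC2)C1=O` gives "not determined" (no result reported) in this assay.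

Among the measured compounds shown here, only two numbers are in hand, and compound 2 holds the higher of them, the weaker inhibition of the pair. Its nearest neighbour, compound 1, returns a lower number, and that gap lies beyond the usual scatter of repeated measurements. Compound 3 adds a third structure but no value, so it cannot place compound 2 any further.

Compound 4 `O=C(CN1CN(c2ccccc2)C2(CCN(C(=O)c3ccc(C4CCCCC4)cc3)CC2)C1=O)NCO` keeps the shared core of compound 2 and differs from it in a single place: hydroxy in place of (methoxycarbonyl)methyl on a saturated chain carbon bound to an amide-type nitrogen. For the measured compounds named here, no step between measured compounds touches this part of the molecule, since compound 1 and compound 2 differ elsewhere. With nothing in the series to lean on, the step is expected to be small, most likely none beyond the scatter, and no direction can be claimed with confidence. Compound 4 is therefore estimated at 15000 nM in this assay, with a range from 5000 nM to 45000 nM. This estimate corresponds to an expected step of a 1.2-fold higher number from compound 2 to compound 4 (0.07 log units; within the scatter).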

Compound 4, half-maximal inhibitory concentration: 8300 nM
Compound 4: the middle estimate sits 1.8-fold (0.26 log units) above what was measured, and the stated range covers the measured number.
By their numbers in this assay, from the lowest: compounds 1, 4 and 2 (each within the scatter of the next, the first and the last beyond it).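

Placing hydroxy in place of (methoxycarbonyl)methyl, on a saturated chain carbon bound to an amide-type nitrogen, gives the first step at this position in this assay, and that step is a 1.6-fold lower number from compound 2 to compound 4 (0.19 log units; within the scatter). Read at this one position, a group of 5 heavy atoms with 0 hydrogen-bond donors and a group of 1 heavy atom with 1 hydrogen-bond donor cannot be told apart by this read-out, so the ester of the 2-(methoxycarbonyl)ethyl chain is not needed to hold the number where it stands in this pair. Nothing on hand bears on why the two structures read alike.

What the two readings at this position cannot show is how far the group can vary before the number moves beyond the scatter: a carboxylic acid at the end of the 2-(methoxycarbonyl)ethyl chain, a primary amine in place of hydroxy, or a longer chain ending in hydroxy could each read differently. On these data alone, it also remains open whether (hydroxymethyl)carbamoyl would match (2-(methoxycarbonyl)ethyl)carbamoyl in the same way on a different core.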